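This account rests on a few compounds, and the source may have more. Where it says the series, first, only, none or still open, it means among the compounds named here.

Three compounds sharing one core were tested in an ADME assay on SH-SY5Y cells (Homo sapiens) for cytotoxicity, read by MTT assay, with a stated time of 48 h; a lower number here means a stronger inhibitor, a higher number a weaker inhibitor. Compound 1 `CCCNC(=O)c1ccc(/C=C/C(=O)c2ccc(OC)cc2O)cc1` reaches only the limit of that assay, > 100000 nM. Compound 2 `CCOCCOc1ccc(/C=C/C(=O)c2ccc(OC)cc2O)cc1` likewise gives only a limit, > 100000 nM. Compound 3 `COc1ccc(C(=O)/C=C/c2cc(OC)c(OC)c(OC)c2)c(O)c1` also stops at a limit, > 100000 nM. For the measured compounds named here, the one step that can be traced, a step that the two limits leave unreadable from compound 1 to compound 2, cannot be read: both of its ends sit at the limit, (the limit of > 100000 nM in this assay, at which 3 of the 3 values shown sit). Compound 2 therefore stands at the limit, and no finer placement among the three is known. Compound 4 `COc1ccc(C(=O)/C=C/c2ccc(OCc3ccccc3)cc2)c(O)c1` differs from compound 2 by phenyl in place of ethoxymethyl on a saturated chain carbon bound to an oxygen on an aromatic ring. Going by the values given here, no measured step bears on this change in a readable way, and the three values show no difference larger than the scatter between any two of them. The step from compound 2 to compound 4 is therefore expected to be small, a step that the limit leaves unreadable from compound 2 to compound 4. Compound 4 is estimated at 150000 nM, with a range from 60000 nM to 400000 nM, and is most likely to be reported once more as a limit rather than a number.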

Compound 4, half-maximal inhibitory concentration: > 100000 nM
Compound 4: a limit, no number; the forecaster's own chance of this, stated with the estimate: 80%; the middle value does not contradict the limit.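

No new step can be read from compound 2 to compound 4 or from compound 1 to compound 4, because neither pair yields a number: the limit of > 100000 nM in this assay, at which 4 of the 4 values shown sit.

The compounds shown leave open how far beyond that limit each one lies, and whether any change to the shared core would give a measurable value in this assay.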